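The compounds below may be only part of what the source reports. "The series", "measured", "known", "first", "only" and "open" are said of these compounds alone.

In a functional assay on Vero cells (Chlorocebus sabaeus) for cytotoxicity (on this read-out higher numbers stand for weaker inhibition and lower numbers for stronger inhibition), two compounds have been tested so far. Compound 1 `OC[C@H]1O[C@@H](n2cnc3c(O)ncnc32)C[Se]1` gives only a limit of the assay, > 100000 nM, and no number. Compound 2 `Nc1ncnc2c1ncn2[C@@H]1C[Se][C@@H](CO)O1` likewise gives only a limit, > 100000 nM. For the measured compounds named here, compound 2 therefore stands at the same point as the one other value shown, namely (the limit of > 100000 nM in this assay, at which 2 of the 2 values shown sit). Compound 3 `OC[C@H]1O[C@H](n2cnc3c(O)ncnc32)C[Se]1` is derived from compound 2 by a single change: hydroxy in place of amino on an aromatic carbon. Going by the values given here, no step between two measured compounds exists to show what this change does on its own, so any expectation rests only on the two limits already described. With compound 1 and compound 2 both sitting at the limit, no shift beyond the usual scatter is expected in this assay. For compound 3 the expected step is a step that the limit leaves unreadable from compound 2 to compound 3, which amounts to no real change. The estimated value for compound 3 is 150000 nM, in a range from 50000 nM to 500000 nM, most likely reported again only as a limit.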

Compound 3, half-maximal inhibitory concentration: > 100000 nM
Compound 3: a limit, no number (the forecaster's own chance of this, stated with the estimate: 85%); the middle value does not contradict the limit.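

Compound 3 also gives only a limit in this assay, so no step to it from compound 1 or compound 2 can be read: the limit of > 100000 nM in this assay, at which 3 of the 3 values shown sit.

Whether hydroxy in place of amino, or the difference in configuration between compound 1 and compound 3, alters the read-out at all stays open, as does the concentration at which any of these compounds would begin to inhibit.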